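Ethyl on the Carbamoyl Nitrogen with Both Anchors Inactive

A few compounds are considered here, and "the series" means these few. Any claim that something is new, unique, unknown or untested is made for them only; others in the source may bear on it.

Compound 1 `CCNC(=O)N1CCN(C(=S)SCc2cn(Cc3ccccc3F)nn2)CC1`: > 128000 nM, a limit of the assay
Compound 2 `NC(=O)N1CCN(C(=S)SCc2cn(Cc3ccc(F)cc3)nn2)CC1`: > 128000 nM, a limit of the assay

In a functional assay on SMMC-7721 cells (Homo sapiens) for cytotoxicity, read by MTT assay, with a stated time of 72 h (on this read-out lower numbers stand for stronger inhibition and higher numbers for weaker inhibition), compound 1 gives only > 128000 nM, which is a limit of the assay and not a number. Compound 2 likewise reaches only > 128000 nM in this assay, again a limit rather than a measured value. Compound 2 therefore stands at the ceiling of what the assay reports, and it is not alone there: both values shown sit at the limit of > 128000 nM in this assay, at which 2 of the 2 values shown sit. Compound 3 `CCNC(=O)N1CCN(C(=S)SCc2cn(Cc3ccc(F)cc3)nn2)CC1` has not yet been measured; it differs from compound 2 by ethyl in place of hydrogen on an amide-type nitrogen, in words ethyl in place of hydrogen on an amide-type nitrogen. Among the measured compounds shown here, no step between two measured compounds is available to size this change directly. Compound 1 carries the same ethylcarbamoyl group on the shared core and also sits at the limit. The expected step is a step that the limit leaves unreadable from compound 2 to compound 3, none beyond the scatter, with compound 3 most likely again reported as a limit. Compound 3 is thus estimated at about 200000 nM, within 100000 nM to 600000 nM.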

Compound 3, half-maximal inhibitory concentration: 44400 nM
Compound 3: middle estimate off by 4.5-fold (0.65 log units), on the high side; measured number outside the range, below it.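

Among the compounds shown here, with ethyl in place of hydrogen on an amide-type nitrogen, this assay shows an at least 2.8-fold lower number from compound 2 to compound 3 (0.45 log units; beyond the scatter), and compound 3 is the only one of the three compounds with a value that is not a limit. The ethylcarbamoyl group is not enough by itself, since compound 1 carries it too, and 4-fluorophenyl in place of 2-fluorophenyl gives an at least 2.8-fold lower number from compound 1 to compound 3 (0.45 log units; beyond the scatter); among these compounds, a measurable value appears only where ethylcarbamoyl and 4-fluorophenyl occur together. Compound 1 and compound 2 each stop at a limit of the assay and not at a number, so both steps are known only as minimum sizes because their starting points are limits: the limit of > 128000 nM in this assay, at which 2 of the 3 values shown sit.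

The compounds shown leave open whether a propyl group, a longer chain or a cyclopropyl ring on this nitrogen would lower the number further or raise it again. For the compounds shown here, they also leave open whether chlorine in place of the fluorine on the phenyl ring would keep the value of compound 3, which at 44400 nM remains the only measured number in this small set.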